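The compounds below may be only part of what the source reports. "The series", "measured", "known", "first", "only" and "open" are said of these compounds alone.

Working notes on the series. In an assay on nucleic acid for inhibition of Nucleic Acid, read by fluorescence, tested at 100 uM (on this read-out higher numbers stand for more inhibition at the one concentration tested (going by the name of the read-out) and lower numbers for less inhibition), compound 1 `O=C(OCC(O)Cn1cc(CN2CCN(c3ccccc3)CC2)nn1)c1ccccc1` gives 11%; compound 2 `O=C(OC1CCCCC1n1cc(CN2CCC(c3ccccc3)CC2)nn1)c1ccccc1` gives 16% in this assay, and the two numbers lie within the scatter of each other, so neither can be set above the other. Compound 3 `CCCCCCCC(=O)OCC(O)Cn1cc(CN2CCN(c3ccccc3)CC2)nn1` is not yet measured in this assay. It differs from compound 1 by heptyl in place of phenyl on a carbonyl carbon. Within the data shown here, no measured pair shows what such a change does here, so only a step within the scatter is expected, with no set direction. For compound 3 the expected step is a number 1 percentage points higher from compound 1 to compound 3 (within the scatter). Compound 3 is estimated at 12%, between 0% and 28%.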

Compound 3, a percentage reported as inhibition, at one concentration (the size of the read-out at that concentration, not a potency): 26%
Estimate against measurement, compound 3: 14 percentage points below, within the range that was stated.
By their numbers in this assay, from the lowest: compounds 1, 2 and 3 (each within the scatter of the next, the first and the last beyond it).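

Among these compounds, at this position, on a carbonyl carbon, heptyl in place of phenyl gives a number 15 percentage points higher from compound 1 to compound 3 (beyond the scatter) in this assay, the first step that lies beyond the scatter. An aromatic ring at this place is therefore not required for the read-out, and an open chain does at least as well here. Nothing measured bears on the cause of this step.

From the compounds shown here alone, whether a shorter chain such as butyl, a longer chain such as decyl, or a chain ending in an amine would move the number further stays open. So does whether heptyl gives a similar step on the core of compound 2.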